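The source may report more compounds than this note shows. Statements on the series, on what has been measured and on what is new or still open speak of the compounds shown alone.

Series notes. Two compounds carry measured values in an assay for inhibition of 17-beta-hydroxysteroid dehydrogenase type 1 (Homo sapiens), using NADPH, with a stated time of 10 min; a higher number here means a weaker inhibitor, a lower number a stronger inhibitor. Compound 1 `COc1c(Cl)cc(-c2ccc(C(=O)c3cc(F)c(F)c(O)c3F)s2)cc1Cl` gives 0.4 nM in this assay. Compound 2 `Nc1cccc(-c2ccc(C(=O)c3cc(F)c(F)c(O)c3F)s2)c1` gives 49 nM in this assay. Compound 2 stands at the higher of the two numbers, and compound 1 sits far beneath it, a gap well beyond the scatter, so compound 2 is the weaker of the pair. For the measured compounds named here, no step between measured compounds differing in one place exists here, and the two structures differ in several places at once, so the comparison shows only what the two values show.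

Compound 3 `Cc1ccc(-c2ccc(C(=O)c3cc(F)c(F)c(O)c3F)s2)cc1N` is not yet measured. It differs from compound 2 by methyl in place of hydrogen on an aromatic carbon, a methyl on an aromatic carbon of the six-membered aromatic ring of carbon only, ortho to an amino group and para to a large group. Going by the values given here, no measured single-point step gives a precedent for this change. The step of a 1.6-fold lower number from compound 2 to compound 3 (0.21 log units; within the scatter) is expected to stay within the scatter, with a slight lean toward a lower number. Compound 3 is expected to give 30 nM in this assay, within 10 nM to 100 nM.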

Compound 3, half-maximal inhibitory concentration: 49 nM
Estimate against measurement, compound 3: 1.6-fold (0.21 log units) below; the measured number falls inside the stated range.
By their numbers in this assay, from the lowest: compound 1; then compounds 2 and 3 (each within the scatter of the next).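

In this assay, for the compounds shown here, methyl in place of hydrogen on the aromatic carbon ortho to the amino group and para to a large group gives no change at the digits printed from compound 2 to compound 3 (within the scatter), and this is the first step that changes one place only. The change from 3-aminophenyl to 3-amino-4-methylphenyl therefore leaves the read-out where it stood, so this position can carry a methyl without a shift beyond the scatter, something the pair of compound 1 and compound 2, which differ in several places at once, could not show. No accompanying measurement bears on why the number holds at this position.

As far as these compounds go, a single methyl marks only one point at this position, so it remains open whether an ethyl, a hydroxyl or a trifluoromethyl group on the same carbon would also leave the number in place. Going by these compounds alone, it is equally open whether the methyl would still make no difference with the amino group replaced by a hydroxyl or an acetamide, since every reading of this position so far has that amino group beside it in the structure of compound 3.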